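Aryl swap on the amide nitrogen: cytotoxicity outlook

A few compounds are considered here, and "the series" means these few. Any claim that something is new, unique, unknown or untested is made for them only; others in the source may bear on it.

Compound 1 `Cc1ccc(NC(=O)C(=O)NC(c2nc(C)c(CCO)s2)C2CCCCN2)cc1F` is the starting point of this comparison. In an ADME assay on TZM-b1 cells (Homo sapiens) for cytotoxicity, read by XTT assay, with a stated time of 3 days (on this read-out higher numbers stand for lower toxicity in this test and lower numbers for higher toxicity in this test), compound 1 gives only a limit, > 85000 nM. Compound 1 therefore stands at a limit rather than at a number, and the two further values shown are limits as well.

Compound 2 `Cc1ccc(NC(=O)C(=O)NC(c2nc(C)c(CO)s2)C2CCCCN2)cc1F` differs from compound 1 by hydroxy in place of hydroxymethyl on a saturated chain carbon bound to an aromatic carbon. In this assay compound 2 also gives a limit, > 88000 nM. The step that the two limits leave unreadable from compound 1 to compound 2 thus cannot be sized. Compound 3 `CC(=O)c1ccc(NC(=O)C(=O)NC(c2nc(C)c(CO)s2)C2CCCCN2)cc1` carries 4-acetylphenyl in place of 3-fluoro-4-methylphenyl on an amide-type nitrogen. In this assay compound 3 gives a limit too, > 86000 nM. Likewise a step that the two limits leave unreadable from compound 2 to compound 3 cannot be sized. (the limit of > 85000 nM in this assay, at which 1 of the 3 values shown sits), the limit of > 86000 nM in this assay, at which 1 of the 3 values shown sits, and the limit of > 88000 nM in this assay, at which 1 of the 3 values shown sits, mark where the whole set sits.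

Compound 4 `Cc1nc(C(NC(=O)C(=O)Nc2ccc(Cl)cc2)C2CCCCN2)sc1CCO` is the next member. It differs from compound 1 by 4-chlorophenyl in place of 3-fluoro-4-methylphenyl on an amide-type nitrogen. Among the measured compounds shown here, the step from compound 2 to compound 3 also exchanges the aryl on the amide-type nitrogen and stayed at the limit, so no measured step reads a size for such a change. No step beyond the scatter is expected, and compound 4 is expected to return a limit once more. The estimated step that the limit leaves unreadable from compound 1 to compound 4 is accordingly close to none. For compound 4 the estimate is 90000 nM, with a range from 40000 nM to 200000 nM.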

Compound 4, half-maximal cytotoxic concentration: 32800 nM
Beside the measured number, compound 4's estimate is 2.7-fold (0.44 log units) above it; the whole stated range lies above it.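

In this assay, the aryl on the amide-type nitrogen is now a place where a change can be read: 4-chlorophenyl in place of 3-fluoro-4-methylphenyl gives an at least 2.5-fold lower number from compound 1 to compound 4 (0.41 log units; beyond the scatter), which on this read-out points towards higher toxicity in this test. Among the compounds shown here, the earlier steps, including the change to 4-acetylphenyl at the same nitrogen, cannot be read, so compound 4 is the only member of the set with a number rather than a limit, and the aryl exchange is not neutral for every aryl group. The size of the step is only a minimum, as its starting point is a limit and not a number: the limit of > 85000 nM in this assay, at which 1 of the 4 values shown sits.

Open, on these data alone, is whether the shift follows the chlorine itself or the loss of the 3-fluoro-4-methylphenyl group, a question that a 4-fluorophenyl, 4-methylphenyl or 4-methoxyphenyl group on the same nitrogen could help to separate. Also open, as far as these compounds go, is whether 4-chlorophenyl gives a similar step when the side chain is the hydroxymethyl group of compound 2 rather than the hydroxyethyl chain of compound 1.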